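Estimating Distribution After a Ring Swap on Compound 1

The compounds below may be only part of what the source reports. "The series", "measured", "known", "first", "only" and "open" are said of these compounds alone.

- compound 1 `Cn1nccc1-c1cc(C(F)(F)F)ccc1[C@H]1CCOc2cc(S(=O)(=O)Nc3nccs3)ccc21`: 2.2 L/kg
- compound 2 `Cn1nccc1-c1cc(C(F)(F)F)ccc1[C@H]1CCOc2cc(S(=O)(=O)Nc3ncccn3)ccc21`: 0.9 L/kg
- compound 3 `Cn1nccc1-c1cc(C(F)(F)F)ccc1[C@H]1CCc2cc(S(=O)(=O)Nc3ncccn3)ccc21`: 0.8 L/kg

In an ADME assay on the whole organism (Mus musculus, strain BALB/c) for pharmacokinetics, read by LC-MS, with a stated time of 24 h, at a dose of 1 mg/kg by the intravenous route (on this read-out higher numbers stand for wider distribution into tissues and lower numbers for narrower distribution), compound 1 gives 2.2 L/kg, the highest of the three numbers, and both other compounds lie beyond the scatter from it. The unmeasured compound 4 `O=S(=O)(Nc1nccs1)c1ccc2c(c1)OCC[C@@H]2c1ccc(C(F)(F)F)cc1-c1ccc(F)nc1` keeps the sulfonamide side of compound 1 and carries 6-fluoropyridin-3-yl in place of 1-methyl-1H-pyrazol-5-yl on an aromatic carbon.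

For the measured compounds named here, no measured step touches this place. Going by the values given here, the only step available, a 2.4-fold lower number from compound 1 to compound 2 (0.39 log units; beyond the scatter), is a modest one and concerns the group on a sulfonamide nitrogen instead, so it offers a rough sense of size for one local change and no guide to direction. With that evidence, the change in this assay is expected to stay small, and the expected step is a 1.1-fold higher number from compound 1 to compound 4 (0.04 log units; within the scatter). The estimated value for compound 4 is 2.4 L/kg. Its expected range runs from 1.2 L/kg to 4.8 L/kg.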

Compound 4, volume of distribution at steady state: 2.9 L/kg
Compound 4: middle estimate off by 1.2-fold (0.08 log units), on the low side; low and high end bracket the measured number.
By their numbers in this assay, from the lowest: compounds 3 and 2 (each within the scatter of the next); then compounds 1 and 4 (each within the scatter of the next).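

In this assay the swap at this position gives a 1.3-fold higher number from compound 1 to compound 4 (0.12 log units; within the scatter) and so stays within the usual scatter. For the compounds shown here, this is the first measured change on the aromatic carbon ortho to a large group and meta to a trifluoromethyl group, and it shows that, with 1,3-thiazol-2-yl kept on the sulfonamide nitrogen, a five-membered aromatic ring can give way to a six-membered one carrying fluorine without a step that can be told from the scatter. Nothing shown explains why the number holds across this change.

The compounds shown leave open whether an amine or a carboxylic acid on this aromatic carbon would move the number beyond the scatter. They also leave open whether 6-fluoropyridin-3-yl would give a similar result with pyrimidin-2-yl on the sulfonamide nitrogen.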